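A few compounds are considered here, and "the series" means these few. Any claim that something is new, unique, unknown or untested is made for them only; others in the source may bear on it.

Measured compounds:
- Compound 1, `Cc1ccccc1S(=O)(=O)Nc1ccc2oc(-c3ccccc3)nc2c1`: in an ADME assay on HEK293 cells (Homo sapiens) for cytotoxicity, read by resazurin assay, with a stated time of 48 h (on this read-out lower numbers stand for higher toxicity in this test and higher numbers for lower toxicity in this test), compound 1 gives 57000 nM.
- Compound 2, `CS(=O)(=O)Nc1ccc2oc(-c3ccccc3)nc2c1`: in this assay compound 2 gives > 100000 nM, which is a limit of the assay rather than a number.
- Compound 3, `O=S(=O)(Nc1ccc2oc(-c3ccccc3)nc2c1)c1cccc(F)c1`: in this assay compound 3 gives 68000 nM.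

The three measured compounds share one core and differ only in the group on the sulfonyl sulfur. Compound 3 holds the highest of the two actual numbers, yet its nearest neighbour, compound 1, sits close by: a 1.2-fold higher number from compound 1 to compound 3 (0.08 log units; within the scatter). The step of an at least 1.7-fold higher number from compound 1 to compound 2 (0.24 log units; that floor lies within the scatter) and the step of an at least 1.4-fold lower number from compound 2 to compound 3 (0.16 log units; that floor lies within the scatter) are also small, and compound 2 only gives a limit, as shown by the limit of > 100000 nM in this assay, at which 1 of the 3 values shown sits. So far, swapping one group for another on the sulfonyl sulfur has moved the read-out of this assay little.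

Compound 4, `COc1ccc(Cl)cc1S(=O)(=O)Nc1ccc2oc(-c3ccccc3)nc2c1`, has not yet been measured. It differs from compound 3 as follows: 5-chloro-2-methoxyphenyl in place of 3-fluorophenyl on a sulfonyl sulfur. Both groups are one six-membered aromatic ring of carbon only, as were the two aromatic groups in compound 1 and compound 3, whose values in this assay lie within the scatter of each other. Given that, the expected step of a 1.1-fold lower number from compound 3 to compound 4 (0.05 log units; within the scatter) in this assay is small, with no clear direction beyond the scatter. Compound 4 is therefore estimated at 60000 nM in this assay, with a likely range from 30000 nM to 120000 nM.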

Compound 4, half-maximal cytotoxic concentration: 74000 nM
Compound 4: middle estimate off by 1.2-fold (0.09 log units), on the low side, and the stated range covers the measured number.
By their numbers in this assay, from the lowest: compounds 1, 3 and 4 (each within the scatter of the next). At a limit, above all of these: compound 2.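

This change is a larger one than the earlier swaps between aromatic groups: 5-chloro-2-methoxyphenyl carries more heavy atoms than 3-fluorophenyl and brings a hydrogen-bond acceptor that 3-fluorophenyl lacks, yet in this assay the read-out does not move beyond the scatter, with a 1.1-fold higher number from compound 3 to compound 4 (0.04 log units; within the scatter). The comparison with 2-methylphenyl gives the same picture, with a 1.3-fold higher number from compound 1 to compound 4 (0.11 log units; within the scatter), so the three aromatic groups shown on the sulfonyl sulfur cannot be told apart in this assay. Against methyl, the step can be read only as a floor, which is an at least 1.3-fold lower number from compound 2 to compound 4 (0.13 log units; that floor lies within the scatter).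

Whether methyl truly differs from the aromatic groups stays open, since compound 2 gives a limit and not a number: the limit of > 100000 nM in this assay, at which 1 of the 4 values shown sits. The compounds shown also leave open whether a group of another kind on the sulfonyl sulfur, such as an amine or a carboxylic acid, would move the read-out beyond the scatter, and what a change elsewhere on the shared core would do.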